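This account rests on a few compounds, and the source may have more. Where it says the series, first, only, none or still open, it means among the compounds named here.

Measured in a functional assay on Jurkat cells (Homo sapiens); a higher number here means a weaker inhibitor, a lower number a stronger inhibitor:
- Compound 1 `CC(C)[C@H](NC(=O)COc1cccc2ccccc12)C(=O)N[C@@H](CC(=O)O)C(=O)COc1cccc2ccccc12`: > 100000 nM (a limit of the assay, not a number)
- Compound 2 `CC(C)[C@H](NC(=O)COc1cccc2ccccc12)C(=O)N[C@@H](CC(=O)O)C(=O)COc1ccc2ccccc2c1`: > 100000 nM (a limit of the assay, not a number)
- Compound 3 `CC(C)[C@H](NC(=O)COc1cccc2ccccc12)C(=O)N[C@@H](CC(=O)O)C(=O)COc1ccc(-c2ccccc2)cc1`: 87900 nM

For the measured compounds named here, compound 3 is the only one with an actual number, 87900 nM. Compound 1 and compound 2 both rest at the limit of > 100000 nM in this assay, at which 2 of the 3 values shown sit.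

Compound 4 `CC(C)[C@H](NC(=O)COc1cccc2ccccc12)C(=O)N[C@@H](CC(=O)O)C(=O)COc1cccc(C(F)(F)F)c1` has not yet been measured. It carries 3-(trifluoromethyl)phenyl in place of 4-phenylphenyl on an oxygen on a saturated carbon.

Three measured steps change the group at this same place. Going by the values given here, the first is a step that the two limits leave unreadable from compound 1 to compound 2, which gives no usable size. The other two are an at least 1.1-fold lower number from compound 1 to compound 3 (0.05 log units; that floor lies within the scatter) and an at least 1.1-fold lower number from compound 2 to compound 3 (0.05 log units; that floor lies within the scatter), and neither shows a change beyond the scatter. Among the compounds with values here, with these as the only guides, no step beyond the scatter is expected in this assay. The expected step is a 1.1-fold higher number from compound 3 to compound 4 (0.06 log units; within the scatter). For compound 4 the estimated value is 100000 nM, with an expected range of 35000 nM to 200000 nM, and the assay may well report only a limit.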

Compound 4, half-maximal inhibitory concentration: > 100000 nM
Compound 4 was reported as a limit; the forecaster's own chance of this, stated with the estimate: 60%; the middle value sits exactly at the limit.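

In this assay, 3-(trifluoromethyl)phenyl, with one six-membered aromatic ring where the earlier groups have two, gives an at least 1.1-fold higher number from compound 3 to compound 4 (0.05 log units; that floor lies within the scatter), so this change shows no step beyond the scatter. The steps from compound 1 and from compound 2 to compound 4 cannot be read, as each has a limit at both ends. A one-ring group on this oxygen thus behaves no differently, as far as can be read, from the two-ring groups, and the series still gathers at the top of the measurable range: the limit of > 100000 nM in this assay, at which 3 of the 4 values shown sit.

Left open is whether any group at this place can lower the number beyond the scatter in this assay. Whether an amine or a carboxylic acid on the ring would do so, or a plain methyl group in place of the ring, cannot be told from these compounds.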